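From 4-fluorobenzyl to (1H-benzimidazol-2-yl)methyl in a sulfonamide series

This account rests on a few compounds, and the source may have more. Where it says the series, first, only, none or still open, it means among the compounds named here.

In a functional assay on MGC-803 cells (Homo sapiens) for inhibition, read by MTT assay, with a stated time of 48 h (on this read-out lower numbers stand for stronger inhibition and higher numbers for weaker inhibition), compound 1 `COc1ccc(CN(c2cc(OC)c(OC)c(OC)c2)S(=O)(=O)c2ccccc2)cc1` reaches only a limit of the assay, > 50000 nM. Compound 2 `COc1ccc(CN(c2cc(OC)c(OC)c(OC)c2)S(=O)(=O)c2ccc(C(C)(C)C)cc2)cc1` gives 10300 nM, and compound 3 `COc1cc(N(Cc2ccc(F)cc2)S(=O)(=O)c2ccc(C)cc2)cc(OC)c1OC` gives 3750 nM. Compound 3 thus holds the lowest number shown, and its gap to compound 2 lies beyond the scatter.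

The next step leads to compound 4 `COc1cc(N(Cc2nc3ccccc3[nH]2)S(=O)(=O)c2ccc(C)cc2)cc(OC)c1OC`. The change is 1H-benzimidazol-2-yl in place of 4-fluorophenyl on a saturated chain carbon bound to a sulfonamide nitrogen.

For the measured compounds named here, only one measured step is available, and it bears on this change only loosely: an at least 4.8-fold lower number from compound 1 to compound 2 (0.68 log units; beyond the scatter), with tert-butyl in place of hydrogen on an aromatic carbon. That is a different change at a different place. It shows that numbers in this assay can move beyond the scatter in this set, but it gives no size for the new step. Going by the values given here, with no measured step at this place, the expectation stays anchored on compound 3 at 3750 nM, with wide margins on both sides. The estimate means a 1.3-fold lower number from compound 3 to compound 4 (0.10 log units; within the scatter), a step expected to stay within the scatter and without a firm direction. For compound 4 the expected value is 3000 nM, with an estimated range from 700 nM to 15000 nM.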

Compound 4, half-maximal inhibitory concentration: 1020 nM
Compound 4: the middle estimate sits 2.9-fold (0.47 log units) above what was measured; measured number inside the range.
By their numbers in this assay, from the lowest: compound 4; then compound 3; then compound 2. At a limit, above all of these: compound 1.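

In this assay the group on the saturated chain carbon bound to a sulfonamide nitrogen moves the number on its own: 1H-benzimidazol-2-yl in place of 4-fluorophenyl gives a 3.7-fold lower number from compound 3 to compound 4 (0.57 log units; beyond the scatter). For the compounds shown here, the only earlier step, an at least 4.8-fold lower number from compound 1 to compound 2 (0.68 log units; beyond the scatter), concerned a hydrogen on an aromatic carbon, and compound 2 and compound 3 differ in more than one place, so this position had no reading of its own until now. The entering group carries 1 hydrogen-bond donor and 1 hydrogen-bond acceptor and the leaving group neither, but no measurement shown links the step to these features or gives a reason for it.

The compounds shown leave open whether the step belongs to the whole 1H-benzimidazol-2-yl group or to one part of it, which an imidazolyl, a pyridyl or a benzoxazolyl group at this place could help to separate. Also open, going by these compounds, is whether a step of this size would recur with another sulfonyl partner, such as the 4-tert-butylphenyl group of compound 2.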